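A few compounds are considered here, and "the series" means these few. Any claim that something is new, unique, unknown or untested is made for them only; others in the source may bear on it.

Compound 1 `COc1cc2c(Nc3nc4ccc(C(=O)Nc5c(C)cccc5Cl)cc4s3)ncnc2cc1OCCCN1CCCCC1C` gives 6800 nM in a functional assay on K562 cells (Homo sapiens) for cytotoxicity, read by WST assay, with a stated time of 72 h (on this read-out higher numbers stand for weaker inhibition and lower numbers for stronger inhibition), the higher of the two numbers shown, though only by a gap within the scatter. Compound 2 `COc1cc2c(Nc3nc4ccc(C(=O)Nc5c(C)cc(C)cc5C)cc4s3)ncnc2cc1OCCCN1CCCCC1C` gives 3500 nM, and the step of a 1.9-fold lower number from compound 1 to compound 2 (0.29 log units; within the scatter) swaps the group on the amide-type nitrogen. Compound 3 `COc1cc2c(Nc3nc4ccc(C(=O)Nc5c(C)cccc5Cl)cc4s3)ncnc2cc1OCCCN1CCCCC1` differs from compound 1 by hydrogen in place of methyl on a saturated ring carbon. For the measured compounds named here, no measured step touches that saturated ring, and the one known step was small. No change beyond the scatter is therefore expected. Compound 3 is expected near 6800 nM, within 3000 nM to 15000 nM, so the step of no change at the digits printed from compound 1 to compound 3 (within the scatter) is estimated to be small.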

Compound 3, half-maximal inhibitory concentration: 12500 nM
Compound 3: the middle estimate sits 1.8-fold (0.26 log units) below what was measured; low and high end bracket the measured number.
By their numbers in this assay, from the lowest: compounds 2, 1 and 3 (each within the scatter of the next, the first and the last beyond it).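

Going from 2-methylpiperidin-1-yl to piperidin-1-yl gives a 1.8-fold higher number from compound 1 to compound 3 (0.26 log units; within the scatter) in this assay and is the first measured step at this saturated ring. On this read-out, hydrogen can therefore stand in place of the methyl on this ring carbon without a change that clears the scatter. No measurement shown here offers an explanation for this step.

As far as these compounds go, whether an ethyl group on the same ring carbon, or a morpholin-4-yl ring in place of the piperidine, would move the number beyond the scatter stays open.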